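The source may hold more compounds than are shown below. What is called first, only, known or untested is meant among the compounds shown, and "the series" means these compounds.

Compound 1, `CC(=O)N(C)C(C)C#CCn1ccnc1`, and compound 2, `CC(=O)NCC#CCn1ccnc1`, have both been tested in a functional assay on the whole organism for antagonist activity, with Mus musculus as the target; on this read-out lower numbers stand for an effect already at smaller amounts and higher numbers for an effect only at larger amounts of compound. In this assay, compound 1 gives > 100 mg/kg, which is a limit of the assay and not a number. Compound 2 gives > 100 mg/kg in this assay, and this too is a limit and not a number. Among the compounds with values here, compound 2 therefore has no exact value to serve as a starting point, and no measured step between two compounds is available to show how large a single change can be.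

Compound 3, `CC(=O)N(C)CC#CCn1ccnc1`, is built from compound 2 by one small edit: methyl in place of hydrogen on an amide-type nitrogen. Within the data shown here, the only guide to its effect is the limit of > 100 mg/kg in this assay, at which 2 of the 2 values shown sit. On that thin basis, the expected step that the limit leaves unreadable from compound 2 to compound 3 is no larger than the usual scatter and has no clear direction, and another result reported only as a limit seems more likely than not. The estimated value for compound 3 is 120 mg/kg, with an expected range from 40 mg/kg to 300 mg/kg.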

Compound 3, dose for half-maximal effect: > 100 mg/kg
Compound 3: a limit, no number; the forecaster's own chance of this, stated with the estimate: 70%; the middle value does not contradict the limit.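

No step can be read between compound 2 and compound 3, or between compound 1 and compound 3, because each result in this assay is a limit of the assay and not a number: the limit of > 100 mg/kg in this assay, at which 3 of the 3 values shown sit. The compounds shown leave open at what dose any of them acts, and how far methyl in place of hydrogen on an amide-type nitrogen can shift the result.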